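Bromo Substitution on a Benzylidene Semicarbazide Series

The source may hold more compounds than are shown below. What is called first, only, known or untested is meant among the compounds shown, and "the series" means these compounds.

Compound 1 `O=C(N/N=C/c1ccc(O)cc1)Nc1ccc(Oc2ccnc3[nH]ccc23)c(F)c1` gives 2780 nM in a functional assay on PC-3 cells (Homo sapiens) for antiproliferative activity, read by MTT assay, with a stated time of 72 h; a higher number here means a weaker inhibitor, a lower number a stronger inhibitor. Compound 2 `O=C(N/N=C/c1ccc(O)c(Br)c1)Nc1ccc(Oc2ccnc3[nH]ccc23)c(F)c1` carries bromo in place of hydrogen on an aromatic carbon, placed ortho to a hydroxy group and meta to a large group, and in this assay compound 2 gives 28600 nM, so that a 10-fold higher number from compound 1 to compound 2 (1.01 log units; beyond the scatter). Compound 3 `O=C(N/N=C/c1ccccc1)Nc1ccc(Oc2ccnc3[nH]ccc23)cc1` rests on a different core; how its core differs from that of compound 1 is not broken down here. In this assay compound 3 gives 10200 nM. Compound 4 `O=C(N/N=C/c1ccc(Br)cc1)Nc1ccc(Oc2ccnc3[nH]ccc23)cc1` carries bromo in place of hydrogen on an aromatic carbon, here para to a large group with no hydroxy group present, the same kind of change as from compound 1 to compound 2 but not the same. Because a 10-fold higher number from compound 1 to compound 2 (1.01 log units; beyond the scatter) was large, a weakening step is expected here too, though smaller, and the expected step is estimated as a 2.2-fold higher number from compound 3 to compound 4 (0.33 log units; beyond the scatter). Compound 4 is therefore estimated at 22000 nM, between 7000 nM and 65000 nM.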

Compound 4, half-maximal inhibitory concentration: "not active" (no number reported)
Compound 4: no number reported, and the estimate cannot be compared.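

Within the data shown here, compound 4 is reported as not active in this assay, with no number, so no step from compound 3 to compound 4 can be read. The compounds shown leave open how large the change from phenyl to 4-bromophenyl is here. Nothing given bears on a cause.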